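A few compounds are considered here, and "the series" means these few. Any claim that something is new, unique, unknown or untested is made for them only; others in the source may bear on it.

Measured compounds:
compound 2 `C#CCSc1nc(N/N=C(\C)c2ccccc2O)c2nnn(Cc3ccccc3)c2n1` gives 3820 nM
compound 1 `CCCSc1nc(N/N=C(\C)c2ccccc2O)c2nnn(Cc3ccccc3Cl)c2n1` gives 35000 nM

Both numbers come from a functional assay on MGC-803 cells (Homo sapiens) for antiproliferative activity, read by MTT assay, with a stated time of 72 h; on this read-out lower numbers stand for stronger inhibition and higher numbers for weaker inhibition. Compound 2 stands at the lowest of the two numbers; the nearest, compound 1, gives a higher number, and the gap between them lies beyond the scatter. Compound 1 differs from compound 2 in more than one place, so no single structural step can be read from that pair.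

Compound 3 `C/C(=N\Nc1nc(SCc2ccccc2)nc2c1nnn2Cc1ccccc1)c1ccccc1O` is not yet measured. Set against compound 2 the change is phenyl in place of ethynyl on a saturated chain carbon bound to a sulfur. Among the compounds with values here, no measured pair covers this change, so no step size can be taken from the series. The expectation is a modest shift, if any, in either direction, not clearly beyond the scatter. In this assay compound 3 is expected at 3500 nM, with a range from 900 nM to 14000 nM. The step this estimate means is a 1.1-fold lower number from compound 2 to compound 3 (0.04 log units; within the scatter).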

Compound 3, half-maximal inhibitory concentration: 850 nM
For compound 3 the middle estimate is 4.1-fold (0.61 log units) above the measured one; measured number below the stated range.
By their numbers in this assay, from the lowest: compound 3; then compound 2; then compound 1.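

In this assay, within the data shown here, phenyl in place of ethynyl on a saturated chain carbon bound to a sulfur gives a 4.5-fold lower number from compound 2 to compound 3 (0.65 log units; beyond the scatter), the first step that can be read at a single place. This position therefore responds to the group it carries, and the larger benzylsulfanyl, with its six-membered aromatic ring, is accepted in place of propargylsulfanyl without any loss; the triple bond is not needed for a number at this level. Nothing on hand explains why the number moves with this change.

Open, on these data alone, is whether the aromatic ring itself matters or whether any larger group would do, which a cyclohexylmethyl or a phenethyl group on the sulfur could separate. Also open, as far as these compounds go, is how far a benzyl carrying an amine or a carboxylic acid would be accepted at this place.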